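Swapping a Pyridine for a Pyrazole on an Amide Nitrogen

The source may report more compounds than this note shows. Statements on the series, on what has been measured and on what is new or still open speak of the compounds shown alone.

Among the measured compounds shown here, compound 1 `Cc1ccc(OCC(=O)N(Cc2cccs2)c2ccccn2)cc1` is the only compound in this small set with a numerical result. In an assay on HEK293 cells for agonist activity at transient receptor potential cation channel subfamily M member 8 (Homo sapiens), read by fluorescence and calcium flux, with a stated time of 15 min (on this read-out lower numbers stand for an effect already at smaller amounts and higher numbers for an effect only at larger amounts of compound), compound 1 gives 200 nM. Compound 2 `CCN(Cc1cccs1)C(=O)c1cc2cc(C)ccc2n1C`, built on a different core, is reported as "not active" (no number reported) in this assay and therefore offers no number to compare against. Compound 3 `Cc1ccc(OCC(=O)N(Cc2cccs2)c2c(C)n[nH]c2C)cc1` differs from compound 1 in one place: 3,5-dimethyl-1H-pyrazol-4-yl in place of pyridin-2-yl on an amide-type nitrogen. For the measured compounds named here, no measured pair in this set shows what such a swap does, so the size of the step cannot be read from the data. The entering group adds a hydrogen-bond donor and changes a six-membered ring with one hetero atom into a five-membered ring with two, a noticeable change on the amide-type nitrogen. A modest loss of potency is expected, slightly beyond the usual scatter, so for compound 3 the estimated value is 500 nM with a range from 150 nM to 2000 nM. In this assay the expected step is a 2.5-fold higher number from compound 1 to compound 3 (0.40 log units; beyond the scatter).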

Compound 3, half-maximal effective concentration: 0.3 nM
Compound 3: the middle estimate sits 1700-fold (3.22 log units) above what was measured; measured number below the stated range.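

In this assay, putting 3,5-dimethyl-1H-pyrazol-4-yl in place of pyridin-2-yl on the amide-type nitrogen gives a 670-fold lower number from compound 1 to compound 3 (2.82 log units; beyond the scatter), so the same effect now appears at much smaller amounts of compound. This shows that the group at this place, with the rest of compound 1 unchanged, can strongly shift the read-out, which compound 1 alone could not reveal. Nothing available here explains why the step is so large.

The swap changes several things at once: ring size, the count of hetero atoms, the hydrogen-bond donor and the two methyl groups, and this single pair cannot separate their shares in the step. Going by these compounds, how a pyrazol-4-yl group without the methyl groups, or a phenyl group, would behave at this place remains open.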